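Flipping one ring stereocentre on a butenolide diterpenoid

The source may hold more compounds than are shown below. What is called first, only, known or untested is meant among the compounds shown, and "the series" means these compounds.

Measured so far:
- compound 1, `CC1=C(O)[C@@H](C/C(C)=C\CC[C@H](C)/C=C/C=C(\C)CCCc2ccoc2)OC1=O`, in a functional assay on A549 cells (Homo sapiens) for cytotoxicity (a higher number here means that more compound is needed for the effect, a lower number that less compound is needed), gives 12.3 ug/mL
- compound 2, `CC1=C(O)[C@@H](C/C(C)=C\CC[C@H](C)/C=C/C=C(\C)CCCC2=CCN(CCC(C)C)C2=O)OC1=O`, in this assay gives 4.3 ug/mL
- compound 3, `CCC(C)CN1CC=C(CCC/C(C)=C/C=C/[C@@H](C)CC/C=C(/C)C[C@@H]2OC(=O)C(C)=C2O)C1=O`, in this assay gives 19 ug/mL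

Compound 3 carries the highest number of the three, though compound 1 sits within the usual scatter of it; only compound 2 lies clearly lower. Compound 4, `CCC(C)CN1CC=C(CCC/C(C)=C/C=C/[C@@H](C)CC/C=C(/C)C[C@H]2OC(=O)C(C)=C2O)C1=O`, differs from compound 3 in this way: the two compounds have the same atoms and bonds; at least one stereo element is drawn with a configuration in one of them and without one in the other: 1 of 6 stereo elements differ; a stereocentre at a saturated ring carbon is drawn S in compound 3 and R in compound 4. Going by the values given here, the single measured step, a 2.9-fold lower number from compound 1 to compound 2 (0.46 log units; beyond the scatter), replaced one ring group by another on the chain and says nothing about a stereocentre. Among the compounds with values here, no measured step therefore bears on this change, and no shift beyond the scatter is expected in this assay: the expected step is no change at the digits printed from compound 3 to compound 4 (within the scatter). Compound 4 is estimated at 19 ug/mL, with a range from 8 ug/mL to 45 ug/mL.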

Compound 4, concentration for half-maximal effect: 27.1 ug/mL
Beside the measured number, compound 4's estimate is 1.4-fold (0.15 log units) below it; low and high end bracket the measured number.
By their numbers in this assay, from the lowest: compound 2; then compounds 1, 3 and 4 (each within the scatter of the next, the first and the last beyond it).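

Inverting the saturated ring carbon from S to R gives a 1.4-fold higher number from compound 3 to compound 4 (0.15 log units; within the scatter), so in this assay this stereocentre shows no clear effect. The chain group counts for more: sec-butyl in place of isobutyl gives a 6.3-fold higher number from compound 2 to compound 4 (0.80 log units; beyond the scatter), and the larger ring group, which lowered the number with isobutyl, now gives a 2.2-fold higher number from compound 1 to compound 4 (0.34 log units; beyond the scatter). One caution attaches to the stereocentre comparison: the fact that one of compounds 3 and 4 is drawn with a defined configuration and the other without, at the place where they differ

Still open, going by these compounds, is whether the inversion stays this small with a benzyl group or a longer chain on the amide-type nitrogen in the ring.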